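Compound 3 to compound 4: a step from the limit

The source may report more compounds than this note shows. Statements on the series, on what has been measured and on what is new or still open speak of the compounds shown alone.

In a functional assay on Ishikawa cells (Homo sapiens) for antiproliferative activity, read by CCK-8 assay, with a stated time of 48 h (a higher number here means a weaker inhibitor, a lower number a stronger inhibitor), compound 1 (`O=C(/C=C/CNCCOc1ccc(Oc2c(-c3ccc(F)cc3)sc3cc(O)ccc23)cc1)N1CCCC1`) gives 11300 nM. Compound 2 (`C=CC(=O)NCCOc1ccc(Oc2c(-c3ccc(F)cc3)sc3cc(O)ccc23)cc1`) gives > 25000 nM, which is a limit of the assay and not a number. Compound 3 (`O=C(CCCNCCOc1ccc(Oc2c(-c3ccc(F)cc3)sc3cc(O)ccc23)cc1)N1CCC1`) gives > 25000 nM, also a limit and not a number. Compound 3 therefore stands at the limit of > 25000 nM in this assay, at which 2 of the 3 values shown sit.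

Compound 4 (`C=C(C)C(=O)N1CC(Oc2ccc(Oc3c(-c4ccc(F)cc4)sc4cc(O)ccc34)cc2)C1`) carries 1-((1-methylethenyl)carbonyl)azetidin-3-yl in place of 2-((3-((azetidin-1-yl)carbonyl)propyl)amino)ethyl on an oxygen on an aromatic ring.

Among the compounds with values here, two measured steps bear on this change. With vinylcarbonyl on the amine nitrogen, compound 2 marks the step of an at least 2.2-fold higher number from compound 1 to compound 2 (0.34 log units; beyond the scatter). The other is an at least 2.2-fold higher number from compound 1 to compound 3 (0.34 log units; beyond the scatter). Both end at the limit, so neither gives a true size, and the step that the two limits leave unreadable from compound 2 to compound 3 cannot be read.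

No step beyond the scatter is therefore expected in this assay, and the side chain of compound 1 is absent from compound 4. The estimated step is a number no higher from compound 3 to compound 4 (the limit leaves the size open). For compound 4 the estimate is 25000 nM, with an expected range of 9000 nM to 50000 nM.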

Compound 4, half-maximal inhibitory concentration: 14200 nM
For compound 4 the middle estimate is 1.8-fold (0.25 log units) above the measured one; measured number inside the range.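

In this assay compound 4 gives a number instead of a limit, so a readable value at this place, on an oxygen on an aromatic ring, does not depend on the side chain of compound 1. The change to 1-((1-methylethenyl)carbonyl)azetidin-3-yl gives an at least 1.7-fold lower number from compound 3 to compound 4 (0.24 log units; that floor lies within the scatter), and the same group gives an at least 1.7-fold lower number from compound 2 to compound 4 (0.24 log units; that floor lies within the scatter). Each of these steps starts from a limit of the assay and not a number: the limit of > 25000 nM in this assay, at which 2 of the 4 values shown sit.

Neither step shows how much of the true difference comes from the azetidine ring and how much from the 1-methylethenyl carbonyl group. A propanoyl group on the azetidine nitrogen, or a piperidine ring in place of the azetidine, would bear on that question.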